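The source may hold more compounds than are shown below. What is called first, only, known or untested is meant among the compounds shown, and "the series" means these compounds.

Measured in a functional assay on PANC-1 cells (Homo sapiens), read by microscopy, crystal violet staining and transwell migration, with a stated time of 18 h, in the presence of a further agent that is not named here; on this read-out higher numbers stand for weaker inhibition and lower numbers for stronger inhibition:
compound 1 `CCc1nc(-c2ccc(OC)cc2)n(-c2cccc(C(=O)NCCCCc3ccccc3)c2)n1`: 140 nM
compound 2 `CCc1nc(-c2ccc(OC(F)(F)F)cc2)n(-c2cccc(C(=O)NCCCCc3ccccc3)c2)n1`: 640 nM
compound 3 `CCc1nc(-c2ccc(OC)cn2)n(-c2cccc(C(=O)NCCCCc3ccccc3)c2)n1`: 120 nM

Compound 3 shares the low end of these numbers with compound 1, as a 1.2-fold lower number from compound 1 to compound 3 (0.07 log units; within the scatter) shows. Compound 2 stands apart from it, with a 5.3-fold lower number from compound 2 to compound 3 (0.73 log units; beyond the scatter).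

The next compound is compound 4 `CCc1nc(-c2ccc(O)cc2)n(-c2cccc(C(=O)NCCCCc3ccccc3)c2)n1`, which carries 4-hydroxyphenyl in place of 5-methoxypyridin-2-yl on an aromatic carbon. Among the compounds with values here, two measured steps bear on this change, and neither matches it exactly. The exchange of 4-methoxyphenyl for 5-methoxypyridin-2-yl gave a 1.2-fold lower number from compound 1 to compound 3 (0.07 log units; within the scatter), so the ring exchange alone offers no reason to expect much movement. Changing what sits on the oxygen gave a 4.6-fold higher number from compound 1 to compound 2 (0.66 log units; beyond the scatter), so a change at that oxygen can move the number by a modest amount. Within the data shown here, no measured compound yet carries a hydroxy group on this ring, which leaves the direction uncertain. A small rise is the cautious expectation in this assay. The expected step is a 2.0-fold higher number from compound 3 to compound 4 (0.30 log units; within the scatter). For compound 4 the estimated value is 240 nM, with an expected range from 80 nM to 700 nM.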

Compound 4, half-maximal inhibitory concentration: 220 nM
Estimate against measurement, compound 4: 1.1-fold (0.04 log units) above; low and high end bracket the measured number.
By their numbers in this assay, from the lowest: compounds 3, 1 and 4 (each within the scatter of the next); then compound 2.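

Within the data shown here, the hydroxy group of compound 4 is the first free hydroxy on this ring, and hydrogen in place of methyl on the oxygen gives a 1.6-fold higher number from compound 1 to compound 4 (0.20 log units; within the scatter) in this assay. The exchange of 5-methoxypyridin-2-yl for 4-hydroxyphenyl, which brings in a hydrogen-bond donor and removes the ring nitrogen, gives a 1.8-fold higher number from compound 3 to compound 4 (0.26 log units; within the scatter), so compound 4 stays with compound 1 and compound 3 at this position. Hydrogen in place of trifluoromethyl on the same oxygen gives a 2.9-fold lower number from compound 2 to compound 4 (0.46 log units; beyond the scatter), which shows that, of the three groups seen on this oxygen, hydrogen and methyl read alike and only trifluoromethyl stands apart, in compound 2.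

Three groups on one oxygen do not show whether an ethyl or a longer chain there would read like methyl or like trifluoromethyl, nor how an amine or a carboxylic acid would read in place of the hydroxy group. On these data alone, it also remains open whether a hydroxy group on the 5-methoxypyridin-2-yl ring, in place of its methoxy, would read as compound 4 does. Nothing measured here accounts for why trifluoromethyl alone stands apart.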